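Swapping methoxy for chloro on the benzyl group

The source may report more compounds than this note shows. Statements on the series, on what has been measured and on what is new or still open speak of the compounds shown alone.

In a functional assay on MCF7 cells (Homo sapiens) for cytotoxicity (a lower number here means a stronger inhibitor, a higher number a weaker inhibitor), compound 1 `COc1ccc(Cn2cc(/C=N\NC(=O)c3c[nH]c4ccccc34)c3ccccc32)cc1` gives 12400 nM and compound 2 `COc1ccc(Cn2cc(/C=N\NC(=O)c3c[nH]c4ccccc34)c3ccc(F)cc32)cc1` gives 13100 nM as its reading. Among the measured compounds shown here, these are the only two numbers so far, and they agree within the scatter, so neither compound stands apart. Compound 3 `O=C(N/N=C\c1cn(Cc2ccc(Cl)cc2)c2ccccc12)c1c[nH]c2ccccc12` alters one group of compound 1 chloro in place of methoxy on an aromatic carbon with chloro in place of methoxy on an aromatic carbon, turning 4-methoxybenzyl into 4-chlorobenzyl. For the measured compounds named here, the one measured step of a 1.1-fold higher number from compound 1 to compound 2 (0.02 log units; within the scatter) is small, but it is a different change, fluoro in place of hydrogen on an aromatic carbon, so it bears only indirectly. Going by the values given here, no measured step touches the methoxy, so no shift beyond the scatter is expected in this assay for this swap. The expected step of a 1.2-fold lower number from compound 1 to compound 3 (0.09 log units; within the scatter) is only an estimate. For compound 3 the estimated value is 10000 nM within an expected range of 4000 nM to 25000 nM.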

Compound 3, half-maximal inhibitory concentration: 96700 nM
The estimate for compound 3 lay 9.7-fold (0.99 log units) below the measured number; measured number outside the range, above it.
By their numbers in this assay, from the lowest: compounds 1 and 2 (each within the scatter of the next); then compound 3.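

Changing 4-methoxybenzyl to 4-chlorobenzyl gives, in this assay, a 7.8-fold higher number from compound 1 to compound 3 (0.89 log units; beyond the scatter), so compound 3 is the weakest inhibitor of the three on this read-out. This para position on the benzyl ring is therefore sensitive to what sits there, whereas the fluoro change elsewhere in the molecule gave only a 1.1-fold higher number from compound 1 to compound 2 (0.02 log units; within the scatter). Nothing available here explains why the swap has this effect.

These compounds leave open whether methoxy helps or chloro harms, a question that a plain benzyl group with hydrogen at this position, or a methyl, hydroxy or amine group there, could begin to settle. As far as these compounds go, it also remains open whether the same swap would have a similar effect on compound 2, which carries the fluoro group.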